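Cytotoxicity notes on a cyclopentenone series

This account rests on a few compounds, and the source may have more. Where it says the series, first, only, none or still open, it means among the compounds named here.

Measured so far:
compound 1 `C=CCOc1cc(C2=C(c3cc(OC)c(OC)c(OC)c3)C(=O)C(O)C2)ccc1OC` — > 100 ug/mL
compound 2 `COc1ccc(C2=C(c3cc(OC)c(OC)c(OC)c3)CC(O)C2=O)cc1N` — 16 ug/mL
compound 3 `O/N=C1/CC(O)C(c2ccccc2)=C1c1ccccc1` — > 100 ug/mL

In an ADME assay on HEp-2 cells (Homo sapiens) for cytotoxicity, read by MTT assay, with a stated time of 72 h (on this read-out higher numbers stand for weaker inhibition and lower numbers for stronger inhibition), compound 1 gives > 100 ug/mL, which is a limit of the assay and not a number. Compound 3 also sits at a limit, giving > 100 ug/mL in this assay. Among the compounds with values here, compound 2 is the one compound with a measured number, giving 16 ug/mL in this assay. Within the data shown here, compound 1 thus stands at the limit of > 100 ug/mL in this assay, at which 2 of the 3 values shown sit, and no step between measured compounds that differ in a single place can be stated here.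

Compound 4 `COc1ccc(C2=C(c3cc(OC)c(OC)c(OC)c3)C(=O)C(O)C2)cc1F` differs from compound 1 by fluoro in place of allyloxy on an aromatic carbon. Among the measured compounds shown here, since compound 1 offers only a limit, no measured step supports a size for the change; a step of no more than the usual scatter, in either direction, is expected, which is what an at least 1.2-fold lower number from compound 1 to compound 4 (0.09 log units; that floor lies within the scatter) means. Compound 4 is therefore estimated to give about 80 ug/mL in this assay, within 30 ug/mL to 200 ug/mL, with a real chance that the assay again reports only a limit.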

Compound 4, half-maximal inhibitory concentration: < 1 ug/mL
Compound 4 ended at the assay's limit; the forecaster's own chance of this, stated with the estimate: 55%; middle value at least 80-fold (1.90 log units) from the limit.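

In this assay, within the data shown here, the first step between two compounds differing in one place is an at least 100-fold lower number from compound 1 to compound 4 (2.00 log units; beyond the scatter), so the aromatic carbon ortho to a methoxy group and meta to a large group has a strong bearing on the read-out. The pair's values are both limits of the assay and not numbers, so the printed size of the step is only a floor. The pair now spans both ends of the range shown, and compound 4 alone holds the lower end: the limit of < 1 ug/mL in this assay, at which 1 of the 4 values shown sits.

Open, on these data alone, is whether a chloro group or a carboxylic acid on this carbon would read like fluoro or like allyloxy. Also open, as far as these compounds go, is whether the step comes from the loss of allyloxy or from the entry of fluoro, and how far apart the true values of the pair lie.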